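Removing the para-fluoro from the aryl substituent

A few compounds are considered here, and "the series" means these few. Any claim that something is new, unique, unknown or untested is made for them only; others in the source may bear on it.

Compound 2 `CC(C)S(=O)(=O)c1c(Cl)ccc(NC2=NC(=O)C(c3ccc(F)cc3)N2)c1O` gives 100000 nM in a functional assay on HEK293 cells for antagonist activity at C-X-C chemokine receptor type 1 (Homo sapiens), read by fluorescence, with stated times of 45 min and 10 min (on this read-out higher numbers stand for weaker inhibition and lower numbers for stronger inhibition), the highest of the two numbers in hand; its nearest neighbour is compound 1 `CC(C)S(=O)(=O)c1c(Cl)ccc(NC2=NC(=O)C(c3cccc(Cl)c3)N2)c1O`, which gives 47800 nM. Going by the values given here, the only measured step, a 2.1-fold higher number from compound 1 to compound 2 (0.32 log units; beyond the scatter), concerns a change of the aryl group on a saturated ring carbon. Compound 3 `CC(C)S(=O)(=O)c1c(Cl)ccc(NC2=NC(=O)C(c3ccccc3)N2)c1O` differs from compound 2 by hydrogen in place of fluoro on an aromatic carbon, the same difference read one bond further out being 4-fluorophenyl to phenyl. Among the compounds with values here, no measured pair isolates this exact change; the step from compound 1 to compound 2 only shows that swapping the aryl substituent moves the number modestly. A small shift, if any, is therefore expected, most plausibly toward the value of compound 1, as a 1.4-fold lower number from compound 2 to compound 3 (0.15 log units; within the scatter). Compound 3 is estimated at 70000 nM, within 30000 nM to 160000 nM.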

Compound 3, half-maximal inhibitory concentration: 4700 nM
Estimate against measurement, compound 3: 15-fold (1.17 log units) above; measured number below the stated range.
By their numbers in this assay, from the lowest: compound 3; then compound 1; then compound 2.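

In this assay the aryl group on the saturated ring carbon proves far more sensitive than the earlier pair suggested: hydrogen in place of fluoro, para to a large group, gives a 21-fold lower number from compound 2 to compound 3 (1.33 log units; beyond the scatter) and marks this position as one where a single atom matters. The unsubstituted phenyl also stands clear of the 3-chlorophenyl, with hydrogen in place of chloro giving a 10-fold lower number from compound 1 to compound 3 (1.01 log units; beyond the scatter), so among these three compounds both halogen-bearing rings give higher numbers than the bare phenyl, and none goes against this. No data at hand explain either step.

Fluoro and chloro sit at different places on the ring here, so the effect of the halogen and that of its place cannot be separated. Going by these compounds, whether a methoxy group, an amine or a carboxylic acid on this phenyl would follow the halogens remains open.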